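The source may report more compounds than this note shows. Statements on the series, on what has been measured and on what is new or still open speak of the compounds shown alone.

Compound 1 `CC1SC(c2cccc(C(=O)NCCCCc3ccccc3)c2)N(c2ccc(C3CC3)cc2)C1=O` was tested in an ADME assay on microsomes from liver (Homo sapiens) for metabolic stability, read by LC-MS, using NADPH, with a stated time of 10 min, tested at 0.1 uM (a higher number here means faster removal of the compound, a lower number slower removal), and gives 2010 mL.min-1.g-1. That is the highest of the three numbers measured here. Compound 2 `O=C(NCCCCn1cccn1)c1cccc(C2SCC(=O)N2c2ccccn2)c1` gives 82.1 mL.min-1.g-1 in this assay, and compound 3 `O=C(NCCCCn1cccn1)c1cccc(C2SCC(=O)N2c2cc(F)ccn2)c1` gives 116 mL.min-1.g-1; both sit far below compound 1, but each of them differs from compound 1 in several places at once, so those gaps cannot be traced to a single change.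

Compound 4 `O=C(NCCCCc1ccccc1)c1cccc(C2SCC(=O)N2c2ccc(C3CC3)cc2)c1` is the unmeasured compound. It is the same as compound 1 except for one change: hydrogen in place of methyl on a saturated ring carbon. For the measured compounds named here, the only one-place step measured so far is from compound 2 to compound 3, in which a fluoro replaces a hydrogen on an aromatic carbon; there the number moved as a 1.4-fold higher number from compound 2 to compound 3 (0.15 log units; within the scatter). Going by the values given here, that step concerns a different group on a different ring, so no measured step bears directly on the loss of a methyl from the saturated ring carbon. Among the compounds with values here, with no direct precedent, the expectation is a step in this assay that stays close to the scatter, perhaps a little lower. Compound 4 is therefore expected to give about 1400 mL.min-1.g-1 in this assay, with a range from 500 mL.min-1.g-1 to 4000 mL.min-1.g-1, a change of a 1.4-fold lower number from compound 1 to compound 4 (0.16 log units; within the scatter).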

Compound 4, intrinsic clearance in microsomes: 811 mL.min-1.g-1
Estimate against measurement, compound 4: 1.7-fold (0.24 log units) above, and the stated range covers the measured number.
By their numbers in this assay, from the lowest: compounds 2 and 3 (each within the scatter of the next); then compound 4; then compound 1.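

In this assay, putting hydrogen in place of the methyl on this saturated ring carbon, next to the ring sulfur, gives a 2.5-fold lower number from compound 1 to compound 4 (0.39 log units; beyond the scatter). This is the first one-place change shown at this position, and its size lies beyond the usual scatter of repeated measurements, so this single carbon does register in the read-out, though the step is modest. The only earlier one-place step, a 1.4-fold higher number from compound 2 to compound 3 (0.15 log units; within the scatter), involved a fluoro on an aromatic carbon and stayed within the scatter, and nothing among the compounds shown explains why the number moves with the loss of this methyl.

The compounds shown cover only hydrogen and methyl at this carbon, so it remains open whether an ethyl, a fluorine or a hydroxyl there would take the number further in either direction. On these data alone, it also remains open whether a methyl at the same carbon would bring a step of similar size to compound 2 or compound 3, which carry hydrogen there but differ from compound 4 in other places.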